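Oxime in place of acetyl on the anilide ring

The source may report more compounds than this note shows. Statements on the series, on what has been measured and on what is new or still open speak of the compounds shown alone.

Measured so far in a functional assay on the whole organism (strain albino) for inhibition, with Rattus norvegicus as the target, read by paw edema, with stated times of 30 min and 5 h, at a dose of 0.28 mmol/kg by the oral route; on this read-out lower numbers stand for less inhibition and higher numbers for more inhibition at the one dose given (going by the name of the read-out):
- compound 1, `CCn1c(SCC(=O)Nc2ccc(/C(C)=N/O)cc2)nnc1-c1ccc(OC)c(OC)c1`, gives 73%
- compound 2, `COc1ccc(-c2nnc(SCC(=O)Nc3ccc(/C(C)=N/O)cc3)n2-c2ccccc2)cc1OC`, gives 76%
- compound 3, `C=CCn1c(SCC(=O)Nc2ccc(C(C)=O)cc2)nnc1-c1ccc(OC)c(OC)c1`, gives 64%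

Compound 3 differs from the other two in two ways at once: it carries an allyl group on the aromatic nitrogen, and it carries an acetyl group where compounds 1 and 2 carry the oxime-type group. Its number sits within the scatter of compound 1 and beyond the scatter below compound 2.

Compound 4, `C=CCn1c(SCC(=O)Nc2ccc(/C(C)=N/O)cc2)nnc1-c1ccc(OC)c(OC)c1`, keeps the allyl group of compound 3 and changes only the anilide end: a group of 4 heavy atoms (2 carbon, 1 nitrogen, 1 oxygen; no ring) in place of a group of 3 heavy atoms (2 carbon, 1 oxygen; no ring), on an aromatic carbon. Among the compounds with values here, no measured pair shows this exact change. Within the data shown here, the only measured single step, a number 3 percentage points higher from compound 1 to compound 2 (within the scatter), concerns the group on the aromatic nitrogen and lies within the scatter, so the oxime-bearing compounds 1 and 2 sit close together whatever that group is. Compound 4 joins that oxime series, and its number is therefore expected to land near those of compounds 1 and 2, a modest rise from compound 3 of about a number 8 percentage points higher from compound 3 to compound 4 (within the scatter), close to the edge of the scatter.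

The estimate for compound 4 in this assay is 72%, with a range from 62% to 82%.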

Compound 4, a percentage reported as inhibition, in the whole organism at one dose (the size of the read-out at that dose, not a potency): 79%
Compound 4: middle estimate off by 7 percentage points, on the low side; the range from low to high includes it.
By their numbers in this assay, from the lowest: compounds 3, 1, 2 and 4 (each within the scatter of the next, the first and the last beyond it).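

In this assay, within the data shown here, replacing acetyl with the oxime-type group on the aromatic carbon while keeping the allyl group fixed gives the first direct reading of this change, a number 15 percentage points higher from compound 3 to compound 4 (beyond the scatter), and this step goes beyond the usual scatter of the read-out. Once the oxime-type group is in place, the substituent on the aromatic nitrogen makes no clear difference among the three oxime compounds, since a number 3 percentage points higher from compound 2 to compound 4 (within the scatter) and a number 6 percentage points higher from compound 1 to compound 4 (within the scatter) both lie within the scatter. Nothing measured here explains why the number rises with this change.

This single pair leaves open whether the same change would give a step of similar size with ethyl or phenyl on the aromatic nitrogen, as the acetyl partners of those two compounds are not among those shown. It also leaves open whether the hydroxyl of the oxime-type group matters, which a methyl ether of the oxime could probe, and how a carboxylic acid or an amine would compare at the same place on the ring.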